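The source may report more compounds than this note shows. Statements on the series, on what has been measured and on what is new or still open speak of the compounds shown alone.

In an ADME assay on microsomes from liver (Rattus norvegicus) for metabolic stability (a higher number here means that the compound lasts longer, a lower number that the compound disappears faster), compound 1 (`Nc1nc(NCCNc2ncc(-c3ncc[nH]3)c(-c3ccccc3Br)n2)ccc1[N+](=O)[O-]`) gives > 0.5 h, which is a limit of the assay and not an exact number. Compound 2 (`Nc1nc(NCCNc2ncc(-c3ncc[nH]3)c(-c3ccc(F)cc3F)n2)ccc1[N+](=O)[O-]`) likewise gives only a limit, > 0.5 h. The whole record so far is therefore (the limit of > 0.5 h in this assay, at which 2 of the 2 values shown sit), and compound 2 has no exact place on the scale, only a bound on one side.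

Compound 3 (`Nc1nc(NCCNc2ncc(-c3ncc[nH]3)c(-c3cc(F)ccc3F)n2)ccc1[N+](=O)[O-]`) keeps the shared core and differs in the fluorine pattern of one ring, with 2,5-difluorophenyl in place of 2,4-difluorophenyl on an aromatic carbon. The group stays on the aromatic carbon ortho to a 1H-imidazol-2-yl group.

Among the compounds with values here, only one measured step bears on this change, a step that the two limits leave unreadable from compound 1 to compound 2. It also alters the substituted phenyl group at this place, but it offers no size to carry forward. No step beyond the usual scatter is therefore expected in this assay, in either direction. The estimated step is a step that the limit leaves unreadable from compound 2 to compound 3, and a reading that is again only a limit is expected. For compound 3 the expected half-life is 0.6 h, with an estimated range from 0.4 h to 1.2 h.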

Compound 3, half-life: > 0.5 h
Compound 3 ended at the assay's limit; the forecaster's own chance of this, stated with the estimate: 80%; the middle value does not contradict the limit.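

No step among compound 1, compound 2 and compound 3 can be read in this assay, as each result is a limit of the assay and not an exact number: the limit of > 0.5 h in this assay, at which 3 of the 3 values shown sit.

The compounds shown leave open how long each one actually lasts, and whether 2,5-difluorophenyl, 2,4-difluorophenyl and 2-bromophenyl differ in half-life at all.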